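Adding a Second Methoxy to a Weak Antiproliferative Series

The source may hold more compounds than are shown below. What is called first, only, known or untested is meant among the compounds shown, and "the series" means these compounds.

Of the compounds shown here, three built on one shared core have been tested in a functional assay on MCF7 cells (Homo sapiens) for antiproliferative activity; on this read-out higher numbers stand for weaker inhibition and lower numbers for stronger inhibition: compound 1 `CC/C=C/Cn1c(Cc2cc(OC)c(OC)c(OC)c2)nc2c(N)ncnc21` gives 46800 nM, compound 2 `CCCCCn1c(Cc2cc(OC)c(OC)c(OC)c2)nc2c(N)ncnc21` gives 61700 nM, and compound 3 `COCCn1c(Cc2cc(OC)c(OC)c(OC)c2)nc2c(N)ncnc21` gives 64600 nM. Compound 3 has the highest of the three numbers, yet the steps of a 1.4-fold higher number from compound 1 to compound 3 (0.14 log units; within the scatter) and a 1.0-fold higher number from compound 2 to compound 3 (0.02 log units; within the scatter) both stay within the scatter. Compound 4 `COc1cc(Cc2nc3c(N)ncnc3n2CC(OC)OC)cc(OC)c1OC` differs from compound 3 by methoxy in place of hydrogen on a saturated chain carbon bound to an oxygen on a saturated carbon and a saturated chain carbon. Among the compounds with values here, the one measured step on the same chain, a 1.0-fold higher number from compound 2 to compound 3 (0.02 log units; within the scatter), was flat, and no measured step tests a second methoxy on that carbon, so in this assay no step beyond the scatter is expected in either direction. Compound 4 is therefore expected at about 65000 nM, between 30000 nM and 140000 nM, which means an expected step of a 1.0-fold higher number from compound 3 to compound 4 (0.00 log units; within the scatter).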

Compound 4, half-maximal inhibitory concentration: 72400 nM
Beside the measured number, compound 4's estimate is 1.1-fold (0.05 log units) below it; low and high end bracket the measured number.
By their numbers in this assay, from the lowest: compounds 1, 2, 3 and 4 (each within the scatter of the next).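

In this assay, the saturated chain carbon bound to an oxygen takes a second methoxy without a step beyond the scatter (a 1.1-fold higher number from compound 3 to compound 4 (0.05 log units; within the scatter)). The 2,2-dimethoxyethyl chain also stays within the scatter of the two purely carbon chains (a 1.2-fold higher number from compound 2 to compound 4 (0.07 log units; within the scatter); a 1.5-fold higher number from compound 1 to compound 4 (0.19 log units; within the scatter)), so all the chains shown read alike here. No evidence on the cause of this flat result is available. Still open, as far as these compounds go, is whether an amine, a carboxylic acid or a much longer chain in place of these groups would give a step beyond the scatter.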